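Removing the para-methoxy from a porcupine inhibitor

The compounds below may be only part of what the source reports. "The series", "measured", "known", "first", "only" and "open" are said of these compounds alone.

Compound 2: `COc1ccc(-n2c(SCC(=O)Nc3nc4ccc(C(F)(F)F)cc4s3)nc3c(c2=O)SCC3)cc1` — 100 nM
Compound 1: `COc1ccccc1-n1c(SCC(=O)Nc2nc3ccc(C(F)(F)F)cc3s2)nc2c(c1=O)SCC2` — 30 nM

In an assay on L cells for inhibition of Protein-serine O-palmitoleoyltransferase porcupine (Mus musculus), read by reporter gene assay, with a stated time of 24 h (on this read-out higher numbers stand for an effect only at larger amounts of compound and lower numbers for an effect already at smaller amounts), compound 2 gives 100 nM, the highest of the two numbers; its nearest neighbour is compound 1, and a 3.3-fold higher number from compound 1 to compound 2 (0.52 log units; beyond the scatter) sets the two apart. Compound 3 `O=C(CSc1nc2c(c(=O)n1-c1ccccc1)SCC2)Nc1nc2ccc(C(F)(F)F)cc2s1` differs from compound 2 by hydrogen in place of methoxy on an aromatic carbon. Among the measured compounds shown here, no measured step removes this group outright; the single step from compound 1 to compound 2 only shows that moving the methoxy shifted the number beyond the scatter, which leaves the direction open. Compound 3 is therefore expected to show a 1.7-fold lower number from compound 2 to compound 3 (0.22 log units; within the scatter), an estimate of 60 nM with a range from 20 nM to 250 nM.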

Compound 3, half-maximal effective concentration: 40 nM
Estimate against measurement, compound 3: 1.5-fold (0.18 log units) above, within the range that was stated.
By their numbers in this assay, from the lowest: compounds 1 and 3 (each within the scatter of the next); then compound 2.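

In this assay, losing the methoxy from the 4-methoxyphenyl gives a 2.5-fold lower number from compound 2 to compound 3 (0.40 log units; beyond the scatter) and so the group at this place is not needed for the effect at these amounts. Set against that, a 1.3-fold higher number from compound 1 to compound 3 (0.12 log units; within the scatter) shows that the phenyl and the 2-methoxyphenyl cannot be told apart, which places the earlier gap with the 4-methoxyphenyl alone. The data offer no measurement that explains this.

On these data alone, whether a fluorine or an amine on that same aromatic carbon would read like the hydrogen or like the methoxy stays open. So does the effect of a longer chain there, such as ethoxy.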